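Swapping Cyclopropyl for Methoxyethylamino: Expected Cell Toxicity

The source may hold more compounds than are shown below. What is called first, only, known or untested is meant among the compounds shown, and "the series" means these compounds.

Of the compounds shown here, two have so far been tested in an ADME assay on CHO cells (Cricetulus griseus) for cytotoxicity, read by MTT assay; on this read-out lower numbers stand for stronger inhibition and higher numbers for weaker inhibition. Compound 1 `CNC(=O)c1ccc(-c2cc(=O)[nH]c(-n3nc(C)cc3C)n2)cc1` gives > 50000 nM, which is a limit of the assay rather than a number. Compound 1 thus sits at the limit of > 50000 nM in this assay, at which 1 of the 2 values shown sits. Going by the values given here, compound 2 `Cc1cc(C2CC2)n(-c2nc(C(F)(F)F)cc(=O)[nH]2)n1` gives 78000 nM in this assay and is therefore the only compound with an actual number. Compound 3 `COCCNc1cc(C)nn1-c1nc(C(F)(F)F)cc(=O)[nH]1` differs from compound 2 in one place: (2-methoxyethyl)amino in place of cyclopropyl on an aromatic carbon. Among the compounds with values here, no measured step between two compounds is available, so the size of this step can only be judged from the two values seen. Neither tested compound showed strong cytotoxicity, and nothing in the data points toward a stronger effect, so no step beyond the scatter is expected. Compound 3 is therefore expected to give 80000 nM, with a range from 40000 nM to 160000 nM, which means an estimated step of a 1.0-fold higher number from compound 2 to compound 3 (0.01 log units; within the scatter).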

Compound 3, half-maximal inhibitory concentration: 17000 nM
Compound 3: the middle estimate sits 4.7-fold (0.67 log units) above what was measured; measured number below the stated range.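

This first measured step in this assay shows that the group on the aromatic carbon next to the ring nitrogen matters for cell toxicity: (2-methoxyethyl)amino in place of cyclopropyl gives a 4.6-fold lower number from compound 2 to compound 3 (0.66 log units; beyond the scatter). The position is therefore not neutral, and a change here can move a compound toward stronger cytotoxicity. Compound 1 remains a limit of the assay and not a number: the limit of > 50000 nM in this assay, at which 1 of the 3 values shown sits.

A single step cannot separate the loss of the cyclopropyl ring from the arrival of the amine nitrogen or the ether oxygen in the new group, so the cause of the shift remains open. A plain amine, a morpholine or a longer chain on this same carbon would help tell these apart, and whether the same swap has a similar effect on the core of compound 1 is also unknown.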